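Ester Alkyl Size and Expected Growth Inhibition

This account rests on a few compounds, and the source may have more. Where it says the series, first, only, none or still open, it means among the compounds named here.

Measured compounds:
compound 1 `CC(C)=CCCC(C)CCOC(=O)/C=C/c1ccc(C(C)C)cc1`: 39%
compound 2 `CC(C)OC(=O)/C=C/c1ccc(C(C)C)cc1`: 18%
compound 3 `COC(=O)/C=C/c1ccc(C(C)C)cc1`: 38%

In a functional assay on the whole organism for inhibition, with Brassica rapa subsp. chinensis as the target, with a stated time of 3 days, tested at 100 ppm (a higher number here means more inhibition of growth at the concentration tested, a lower number less inhibition of growth), compound 1 gives 39%, compound 2 gives 18% and compound 3 gives 38%. Compound 3 stands second highest of the three; its nearest neighbour is compound 1, within the scatter, and its furthest is compound 2, beyond the scatter. Within the data shown here, the only step measured in one place is a number 20 percentage points higher from compound 2 to compound 3 (beyond the scatter).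

Compound 4 `CCOC(=O)/C=C/c1ccc(C(C)C)cc1` differs from compound 3 by methyl in place of hydrogen on a saturated chain carbon bound to an oxygen next to a carbonyl group. Among the measured compounds shown here, no measured step is exactly this change; the step that bears on it is the one from compound 2 to compound 3, where shrinking the ester alkyl from isopropyl to methyl raised inhibition modestly. Ethyl is larger than methyl and smaller than isopropyl, so compound 4 is expected to fall slightly below compound 3, by a step of a number 8 percentage points lower from compound 3 to compound 4 (within the scatter), which may not exceed the scatter. The estimate for compound 4 in this assay is 30%, with a range from 12% to 48%.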

Compound 4, percent growth inhibition at one concentration: 44%
Compound 4: the middle estimate sits 14 percentage points below what was measured; low and high end bracket the measured number.
By their numbers in this assay, from the lowest: compound 2; then compounds 3, 1 and 4 (each within the scatter of the next).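

In this assay, methyl in place of hydrogen at this position, which turns methoxycarbonyl into ethoxycarbonyl, gives a number 6 percentage points higher from compound 3 to compound 4 (within the scatter) and so leaves the two esters without a difference that can be read. The isopropyl ester stays apart, with a number 26 percentage points higher from compound 2 to compound 4 (beyond the scatter) and so among these compounds only the methyl on the carbon bound to the ester oxygen goes with a readable difference, while the methyl that extends the chain does not. Compound 1, with its much larger 1,5-dimethylhex-4-en-1-yl-bearing ester, goes against any steady fall with ester size, showing a number 5 percentage points higher from compound 1 to compound 4 (within the scatter) as its step.

Nothing at hand accounts for compound 2 standing apart. Going by these compounds, whether a tert-butyl ester would sit with compound 2, and how a free carboxylic acid in place of the ester would compare, stays open.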